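The source may hold more compounds than are shown below. What is called first, only, known or untested is meant among the compounds shown, and "the series" means these compounds.

Measured compounds:
- compound 1, `C1=C(c2nc3ccccc3o2)CCN(Cc2ccccc2)C1`: in an assay on HEK293 cells for displacement of a labelled ligand from D(4) dopamine receptor (Homo sapiens) (a higher number here means a weaker inhibitor, a lower number a stronger inhibitor), compound 1 gives 97 nM
- compound 2, `Clc1ccc2sc(C3=CCN(Cc4ccccc4)CC3)nc2c1`: in this assay compound 2 gives 44 nM

Compound 2 holds the lower of the two numbers recorded in this assay. Among the measured compounds shown here, the only other measured compound, compound 1, sits higher by a margin that lies beyond the scatter, so compound 2 is the stronger inhibitor of the pair. For the measured compounds named here, the two differ in more than one place, so no single step between them can be read off; their values are simply set side by side.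

Compound 3, `Clc1ccc(CN2CC=C(c3nc4cc(Cl)ccc4s3)CC2)cc1`, is the next compound awaiting measurement in this assay. Relative to compound 2 the change is chloro in place of hydrogen on an aromatic carbon, on the ring that is para to a large group; benzyl becomes 4-chlorobenzyl. Going by the values given here, no measured pair shows this exact change, so its size has no direct precedent here. The working expectation is a small move downward or none beyond the scatter. For compound 3 the estimated value in this assay is 30 nM, within 10 nM to 100 nM, which corresponds to an expected step of a 1.5-fold lower number from compound 2 to compound 3 (0.17 log units; within the scatter).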

Compound 3, inhibition constant: 21 nM
Compound 3: the middle estimate sits 1.4-fold (0.15 log units) above what was measured; the measured number falls inside the stated range.
By their numbers in this assay, from the lowest: compound 3; then compound 2; then compound 1.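

In this assay, the benzyl group now has its first single-place reading: chloro in place of hydrogen on an aromatic carbon, para to a large group, gives a 2.1-fold lower number from compound 2 to compound 3 (0.32 log units; beyond the scatter). This position therefore accepts a chlorine atom without loss, and the change from benzyl to 4-chlorobenzyl moves the number modestly towards a stronger inhibitor, something that compound 1 and compound 2 could not show, as they differ in more than one place. Among the compounds shown here, this single pair is the only reading of the change, and no measurement on hand accounts for the step.

As far as these compounds go, whether the step belongs to chloro in particular stays open, as fluoro, methoxy, an amine or a carboxylic acid at the same place could give a similar step, a larger one or none. Also open, from the compounds shown here alone, are whether 4-chlorobenzyl would give a step of like size on the core of compound 1, and whether a longer chain such as phenethyl in place of benzyl would keep the number of compound 3.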